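Series notes: removing the ring chloro of compound 2

The source may hold more compounds than are shown below. What is called first, only, known or untested is meant among the compounds shown, and "the series" means these compounds.

Three compounds have numbers in a functional assay on HL-60 cells (Homo sapiens) for inhibition, read by MTT assay, with a stated time of 72 h; on this read-out higher numbers stand for weaker inhibition and lower numbers for stronger inhibition. Compound 1 `Cc1nc(-c2ccccc2F)c(C(=O)N2CCN(c3cc(Cl)cc(Cl)c3)CC2)o1` gives 60.2 nM. Compound 2 `Cc1nc(-c2ccccc2)c(C(=O)N2CCN(c3ccccc3Cl)CC2)o1` gives 124 nM. Compound 3 `COc1cc(OC)cc(N2CCN(C(=O)c3onc(C)c3-c3ccc(-c4ccco4)cc3)CC2)c1` gives 191 nM. Compound 2 stands second highest of the three: its nearest neighbour is compound 3, a gap within the usual scatter, and its furthest is compound 1, whose lower number lies beyond the scatter. No pair among these three differs in a single place, so no measured step is available.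

Compound 4 `Cc1nc(-c2ccccc2)c(C(=O)N2CCN(c3ccccc3)CC2)o1` has not yet been measured in this assay. It differs from compound 2 in one place: hydrogen in place of chloro on an aromatic carbon. Read one bond further out, the change is 2-chlorophenyl to phenyl, sited on an aromatic carbon of a six-membered aromatic ring of carbon only, ortho to a large group.

Nothing measured here shows what a chloro at this place contributes. The expected change is a step of a 1.5-fold higher number from compound 2 to compound 4 (0.16 log units; within the scatter), towards a somewhat higher number, though a result within the scatter cannot be excluded. For compound 4 the estimate is 180 nM, with a range from 65 nM to 500 nM.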

Compound 4, half-maximal inhibitory concentration: 39.1 nM
Compound 4: the middle estimate sits 4.6-fold (0.66 log units) above what was measured; measured number outside the range, below it.
By their numbers in this assay, from the lowest: compounds 4 and 1 (each within the scatter of the next); then compounds 2 and 3 (each within the scatter of the next).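

In this assay the chloro at this place is not needed for inhibition: hydrogen in place of chloro on an aromatic carbon, ortho to a large group, gives a 3.2-fold lower number from compound 2 to compound 4 (0.50 log units; beyond the scatter) and so lowers the number beyond the scatter. Going by these compounds alone, with the rest of the structure unchanged, the 2-chlorophenyl to phenyl change therefore favours the plain phenyl, which the three earlier compounds, with no single-place pair among them, could not show. No supporting measurement is available to account for this step.

Still open, from the compounds shown here alone, is whether a different group at this place, such as a nitrile, an amine or a carboxylic acid, would keep the number as low as hydrogen does or raise it. Also open, going by these compounds, is whether the same change gives a step of similar size elsewhere on this ring or on a different core.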